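Fluoro in place of bromo on the isatin ring

The compounds below may be only part of what the source reports. "The series", "measured", "known", "first", "only" and "open" are said of these compounds alone.

Compounds measured so far:
- compound 1, `O=C1C(=O)N(CCCCn2cc(COc3cc(=O)oc4ccccc34)nn2)c2ccc(F)cc21`: 67%
- compound 2, `O=C1C(=O)N(CCCCCn2cc(COc3cc(=O)oc4ccccc34)nn2)c2ccc(Br)cc21`: 43%
- compound 3, `COc1ccc2c(c1)C(=O)C(=O)N2CCCn1cc(COc2cc(=O)oc3ccccc23)nn1`: 52%

In a functional assay on HCT-116 cells (Homo sapiens) for inhibition, read by sulforhodamine B assay, with a stated time of 48 h, tested at 50 uM (a higher number here means more inhibition of growth at the concentration tested, a lower number less inhibition of growth), compound 2 gives 43%, the lowest of the three numbers measured. Its nearest neighbour is compound 3, whose value lies within the scatter of repeated measurements, so no order between compound 2 and compound 3 can be claimed. The furthest is compound 1, whose value lies beyond the scatter above that of compound 2; compound 1 and compound 2 differ in more than one place, so nothing more than the two numbers themselves can be said of that gap.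

Compound 4, `O=C1C(=O)N(CCCCCn2cc(COc3cc(=O)oc4ccccc34)nn2)c2ccc(F)cc21`, has not yet been measured in this assay. It differs from compound 2 in one place only: fluoro in place of bromo on an aromatic carbon. No step between two measured compounds isolates this change, so the expectation rests on the numbers shown. Compound 1 carries the fluoro and gives 67%, compound 2 carries the bromo and gives 43%, but the two also differ in the chain. The step of a number 12 percentage points higher from compound 2 to compound 4 (beyond the scatter) is therefore expected to be a modest rise, near the edge of the scatter. Compound 4 is estimated at 55%, with a range from 38% to 72%.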

Compound 4, percent growth inhibition at one concentration: 59%
The estimate for compound 4 lay 4 percentage points below the measured number; the range from low to high includes it.
By their numbers in this assay, from the lowest: compounds 2, 3, 4 and 1 (each within the scatter of the next, the first and the last beyond it).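

In this assay, within the data shown here, fluoro in place of bromo on an aromatic carbon, with the rest of the structure unchanged, goes with a number 16 percentage points higher from compound 2 to compound 4 (beyond the scatter) and so shows for the first time that this single exchange on the six-membered aromatic ring can by itself shift growth inhibition. Until now, the gap between the fluoro and bromo compounds was tied up with a difference in the chain, whereas compound 1 at 67% and compound 4 at 59% both carry fluoro, differ only in the chain and stand within the scatter of each other. No measurement shown here accounts for the effect of the exchange at this position.

As far as these compounds go, whether chloro or an unsubstituted aromatic carbon at this place would stand with the bromo compound, with the fluoro compound or elsewhere remains open. So does whether the step from bromo to fluoro would hold on a shorter or longer chain, or on a compound ending in an amine or a carboxylic acid on that ring.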